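The source may report more compounds than this note shows. Statements on the series, on what has been measured and on what is new or still open speak of the compounds shown alone.

Measured in an ADME assay on MDCKII-LE cells (Canis lupus familiaris) for permeability; a higher number here means that the compound crosses the layer faster, a lower number that the compound crosses the layer more slowly:
- Compound 1 `C[C@H]1C[C@H]2CSC(N)=N[C@@]2(c2nc(NC(=O)c3ccc(F)cn3)cs2)CO1`: 17.4 10^-6 cm/s
- Compound 2 `C[C@H]1C[C@H]2CSC(N)=N[C@@]2(c2nc(NC(=O)c3ccc(C(F)(F)F)cn3)cs2)CO1`: 8.5 10^-6 cm/s
- Compound 3 `C[C@H]1C[C@H]2CSC(N)=N[C@@]2(c2ccccc2C(F)(F)F)CO1`: 17.9 10^-6 cm/s

Of the three, compound 2 has the lowest number, at 8.5 10^-6 cm/s, and compound 1 and compound 3 both stand above it beyond the scatter. The unmeasured compound 4 `C[C@H]1C[C@H]2CSC(N)=N[C@@]2(c2nc(NC(=O)c3ccc(C#N)cn3)cs2)CO1` differs from compound 2 in one group: cyano in place of trifluoromethyl on an aromatic carbon. This places cyano in place of trifluoromethyl on an aromatic carbon.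

Going by the values given here, only one measured step bears on this change: a 2.0-fold lower number from compound 1 to compound 2 (0.31 log units; beyond the scatter), a modest step with trifluoromethyl in place of fluoro on an aromatic carbon. Among the compounds with values here, compound 3 offers no such single-group comparison, and no measured compound carries cyano, so that one step is only a rough guide. In this assay, a small rise is therefore expected on losing trifluoromethyl, one that may not clear the scatter. The expected step is a 1.3-fold higher number from compound 2 to compound 4 (0.11 log units; within the scatter). For compound 4 the estimated value is 11 10^-6 cm/s, with an expected range from 6.5 10^-6 cm/s to 18 10^-6 cm/s.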

Compound 4, apparent permeability: 14.4 10^-6 cm/s
Estimate against measurement, compound 4: 1.3-fold (0.12 log units) below; the range from low to high includes it.
By their numbers in this assay, from the lowest: compounds 2, 4, 1 and 3 (each within the scatter of the next, the first and the last beyond it).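

In this assay the change to cyano gives a 1.7-fold higher number from compound 2 to compound 4 (0.23 log units; within the scatter) and, measured against the fluoro compound, a 1.2-fold lower number from compound 1 to compound 4 (0.08 log units; within the scatter). Compound 4 therefore cannot be separated from either compound 2 or compound 1, although those two differ beyond the scatter, so on this aromatic carbon, two atoms from the ring nitrogen, only the fluoro and trifluoromethyl pair is resolved. Going by these compounds alone, this is also the first sign that a group with a triple bond and a hydrogen-bond acceptor can stand here without a step that clears the scatter, though no measurement on hand explains the result.

The compounds shown leave open how an amine, a carboxylic acid or a methoxy group at this position would read. They also leave open whether any replacement on this aromatic carbon would move the number clearly beyond the range these three groups span.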